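Swapping a pyridine for a furan on the cyclopropane arm

The compounds below may be only part of what the source reports. "The series", "measured", "known", "first", "only" and "open" are said of these compounds alone.

For the measured compounds named here, compound 2, with the structure `CC[C@H](C)[C@H](N)CN(C(=O)[C@@H]1C[C@H]1c1ccncc1)c1ccc(-c2ccccc2)cc1`, is the only compound of this small set for which a functional assay for agonist activity at G protein-coupled receptor 88 (Homo sapiens), read by HTRF and cAMP accumulation (on this read-out higher numbers stand for an effect only at larger amounts of compound and lower numbers for an effect already at smaller amounts), gives an actual number: compound 2 reaches 1500 nM. Compound 1, `CC[C@H](C)[C@H](N)CN(C(=O)[C@@H]1C[C@H]1c1ccc(OC)cc1)c1ccc(-c2ccccc2)cc1`, gives in this assay only the limit > 25000 nM, a boundary of the measurement rather than a result. Going by the values given here, the one measured step, an at least 16-fold lower number from compound 1 to compound 2 (1.22 log units; beyond the scatter), shows that exchanging one aromatic ring on the saturated ring carbon shifts the read-out strongly, and it rests on (the limit of > 25000 nM in this assay, at which 1 of the 2 values shown sits).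

Compound 3, `CC[C@H](C)[C@H](N)CN(C(=O)[C@@H]1C[C@H]1c1ccoc1)c1ccc(-c2ccccc2)cc1`, carries the change (furan-3-yl in place of pyridin-4-yl on a saturated ring carbon). Among the compounds with values here, no measured step tells how a five-membered oxygen ring compares with the six-membered nitrogen ring here; only the large sensitivity of this position to such an exchange is known. The step of a 2.7-fold higher number from compound 2 to compound 3 (0.43 log units; beyond the scatter) is therefore expected to run toward a higher number, and compound 3 is estimated at 4000 nM, within 1000 nM to 20000 nM.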

Compound 3, half-maximal effective concentration: 580 nM
Estimate against measurement, compound 3: 6.9-fold (0.84 log units) above; the whole stated range lies above it.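

For the compounds shown here, until now this saturated ring carbon was known only to respond to a change of aromatic ring, and only one of the two values was an actual number. In this assay, two actual numbers can now be compared, and the five-membered oxygen ring gives the lower one, with a 2.6-fold lower number from compound 2 to compound 3 (0.41 log units; beyond the scatter). That modest step contrasts with an at least 43-fold lower number from compound 1 to compound 3 (1.63 log units; beyond the scatter), but this larger figure is a minimum rather than an exact size, and it rests on a limit of the assay: the limit of > 25000 nM in this assay, at which 1 of the 3 values shown sits.

The compounds shown leave open whether the gain follows the ring size or the oxygen atom, which a thiophene ring or an unsubstituted phenyl ring on the same carbon could help to separate. On these data alone, how an amine or a carboxylic acid on the ring would read in this assay also remains open.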